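The source may hold more compounds than are shown below. What is called first, only, known or untested is meant among the compounds shown, and "the series" means these compounds.

Measured so far:
- compound 1, `Cc1ccc(S(=O)(=O)CCO)cc1C#Cc1cc(Cl)ccc1OCC(=O)O`, 19 nM
- compound 2, `CS(=O)(=O)c1ccc(F)c(C#Cc2cc(Cl)ccc2OCC(=O)O)c1`, 3.3 nM

In an assay on CHO cells for displacement of a labelled ligand from prostaglandin D2 receptor 2 (Homo sapiens), read by scintillation counting (on this read-out lower numbers stand for stronger inhibition and higher numbers for weaker inhibition), compound 2 gives 3.3 nM, the lower of the two numbers, while compound 1 gives 19 nM; the gap between these two values lies beyond the usual scatter of this assay, so compound 2 is the stronger binder of the pair. Compound 3, `Cc1ccc(S(C)(=O)=O)cc1C#Cc1cc(Cl)ccc1OCC(=O)O`, has not yet been measured. It differs from compound 2 in one place: methyl in place of fluoro on an aromatic carbon. Among the measured compounds shown here, no step of exactly this kind has been measured here. Compound 1 also carries a methyl on that aromatic carbon and gives 19 nM, but it differs from compound 3 in a second place as well, so it offers only a loose guide. Compound 3 is expected to stay near compound 2, with a small step of a 1.5-fold higher number from compound 2 to compound 3 (0.18 log units; within the scatter) toward a weaker result that may not exceed the scatter. Compound 3 is estimated to give 5 nM in this assay, within a range from 1.5 nM to 15 nM.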

Compound 3, inhibition constant: 5 nM
The estimate for compound 3 equals the measured number at the digits printed; measured number inside the range.
By their numbers in this assay, from the lowest: compounds 2 and 3 (each within the scatter of the next); then compound 1.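

In this assay, the step of methyl in place of fluoro on this aromatic carbon, para to a methylsulfonyl group, is a 1.5-fold higher number from compound 2 to compound 3 (0.18 log units; within the scatter), so the read-out does not tell these two groups apart here. Among the compounds shown here, compound 3 also isolates the sulfonyl side for the first time, since the gap between compound 1 and compound 2 mixed two changes: with methyl on the aromatic carbon in both compounds, replacing hydroxymethyl with hydrogen on the saturated chain carbon bound to a sulfonyl sulfur gives a 3.8-fold lower number from compound 1 to compound 3 (0.58 log units; beyond the scatter). Nothing available here explains the size of either step.

From the compounds shown here alone, it remains open what a methoxy group or a nitrile would give on that aromatic carbon. Also open, going by these compounds, is how an amine or a longer chain on the sulfonyl sulfur would compare.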